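Chain-terminal aryl variation in the ACAT amide series

This account rests on a few compounds, and the source may have more. Where it says the series, first, only, none or still open, it means among the compounds named here.

Measured so far in an assay for inhibition of acyl-CoA:cholesterol acyltransferase (Oryctolagus cuniculus), using microsomes; a lower number here means a stronger inhibitor, a higher number a weaker inhibitor:
compound 1 `CCCCCCCCCCCCC(C)(C)C(=O)Nc1c(C)cc(C)c2c1OC(C)(C)C2` gives 33 nM
compound 2 `Cc1cc(C)c(NC(=O)C(C)(C)CCCCCCN2CCCCC2)c2c1CC(C)(C)O2` gives > 500 nM
compound 3 `Cc1cc(C)c(NC(=O)C(C)(C)CCCCCc2ccccc2)c2c1CC(C)(C)O2` gives 120 nM

The value for compound 2 is a limit of this assay, not a number (the limit of > 500 nM in this assay, at which 1 of the 3 values shown sits). Among the two numbers shown, compound 3 sits highest; its nearest neighbour is compound 1, from which it is separated by the step of a 3.6-fold higher number from compound 1 to compound 3 (0.56 log units; beyond the scatter).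

Compound 4 `Cc1cc(C)c(NC(=O)C(C)(C)CCCCCCc2ccccc2)c2c1CC(C)(C)O2` is compound 3 with one change: benzyl in place of phenyl on a saturated chain carbon, six bonds along the chain from a carbonyl carbon. The change extends the aromatic substituent by a single saturated carbon and brings the chain one bond closer to the length found in compound 1. Going by the values given here, three measured steps bear on the terminal group at this place: a 3.6-fold higher number from compound 1 to compound 3 (0.56 log units; beyond the scatter), an at least 4.1-fold lower number from compound 2 to compound 3 (0.61 log units; beyond the scatter) and an at least 15-fold higher number from compound 1 to compound 2 (1.18 log units; beyond the scatter). The first two are modest, the third large. The third step exchanges hexyl for piperidin-1-yl, a group that compound 4 does not carry. Adding one carbon between chain and phenyl is a smaller alteration than any of these, so the expected step is a 1.3-fold lower number from compound 3 to compound 4 (0.12 log units; within the scatter), that is, within the scatter or a slightly lower number.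

Compound 4 is therefore expected to give 90 nM in this assay, with a range from 40 nM to 250 nM.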

Compound 4, half-maximal inhibitory concentration: 81 nM
Estimate against measurement, compound 4: 1.1-fold (0.05 log units) above; the range from low to high includes it.
By their numbers in this assay, from the lowest: compound 1; then compounds 4 and 3 (each within the scatter of the next). At a limit, above all of these: compound 2.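

In this assay, one further saturated carbon at the chain end gives a 1.5-fold lower number from compound 3 to compound 4 (0.17 log units; within the scatter), so benzyl and phenyl are not told apart at this position, and the result sets no direction for chain extension here. The wider comparisons at seven bonds along the chain from a carbonyl carbon read a 2.5-fold higher number from compound 1 to compound 4 (0.39 log units; beyond the scatter) and an at least 6.1-fold lower number from compound 2 to compound 4 (0.79 log units; beyond the scatter), both beyond the scatter, so the phenyl-ended chain of compound 4 stays weaker than the all-carbon chain of compound 1 and stronger than the piperidin-1-yl chain of compound 2, the same placing already seen for compound 3. The second of these steps has only one bound, since compound 2 is held at a limit and not a number: the limit of > 500 nM in this assay, at which 1 of the 4 values shown sits.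

Open, going by these compounds, is whether phenethyl, 3-phenylpropyl or 4-phenylbutyl in place of benzyl would stay level with compound 4 or move towards compound 1. Also open, on these data alone, is how a phenyl ring carrying a methoxy group or a chlorine atom, or a chain ending in a carboxylic acid or a hydroxyl group, would read at this place.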